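Two analogues at the assay limit and a styryl variant

The source may hold more compounds than are shown below. What is called first, only, known or untested is meant among the compounds shown, and "the series" means these compounds.

compound 1 `C=C[C@@](C)(/C=C/c1ccc(O)c(/C=C/C(=O)OCc2ccccc2)c1)CCC=C(C)C`: > 43400 nM
compound 2 `C=C[C@@](C)(/C=C/c1ccc(O)c(/C=C/c2ccc(F)cc2)c1)CCC=C(C)C`: > 43400 nM

In a functional assay on NALM-6 cells (Homo sapiens) for cytotoxicity, with a stated time of 72 h (a lower number here means that less compound is needed, a higher number that more compound is needed for the effect), compound 1 gives only the limit > 43400 nM, not a number. Compound 2 likewise gives only the limit > 43400 nM in this assay. The step that the two limits leave unreadable from compound 1 to compound 2 therefore cannot be sized, since (the limit of > 43400 nM in this assay, at which 2 of the 2 values shown sit). Compound 3 `C=C[C@@](C)(/C=C/c1ccc(O)c(/C=C/C=C/c2ccccc2)c1)CCC=C(C)C` differs from compound 2 by 2-phenylethenyl in place of 4-fluorophenyl on a double-bonded chain carbon bound to a double-bonded chain carbon. Within the data shown here, only that unreadable step bears on this change, so no direction beyond the scatter can be expected for compound 3 in this assay; compound 3 is expected to stay at or near the limit, with an estimated 50000 nM (range 15000 nM to 150000 nM). The step this estimate implies for compound 3 is expected to be a step that the limit leaves unreadable from compound 2 to compound 3.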

Compound 3, half-maximal effective concentration: > 43400 nM
Compound 3: no number, only a limit; the forecaster's own chance of this, stated with the estimate: 80%; the middle value does not contradict the limit.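

In this assay, among these compounds, no step among compound 1, compound 2 and compound 3 can be read, because all three give only a limit: the limit of > 43400 nM in this assay, at which 3 of the 3 values shown sit. These compounds leave open which group at this place, if any, would give a measurable value.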